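Extending the Ether Chain of Compound 2

The source may hold more compounds than are shown below. What is called first, only, known or untested is meant among the compounds shown, and "the series" means these compounds.

Of the compounds shown here, two with a shared core have been tested in an ADME assay on RAW264.7 cells (Mus musculus) for cytotoxicity, read by MTT assay, with a stated time of 24 h, in the absence of a further agent; on this read-out higher numbers stand for weaker inhibition and lower numbers for stronger inhibition. Compound 1 (`CCOc1ccc(C(O)C2OC(=O)c3c(OC)cc(OC)cc32)cc1`) gives > 40000 nM, which is a limit of the assay and not a number. Compound 2 (`COCCOc1ccc(C(O)C2OC(=O)c3c(OC)cc(OC)cc32)cc1`) gives > 40000 nM, which is again a limit. Going by the values given here, compound 2 therefore has no exact position, and the only reading available is the limit of > 40000 nM in this assay, at which 2 of the 2 values shown sit.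

Compound 3 (`COCCCOc1ccc(C(O)C2OC(=O)c3c(OC)cc(OC)cc32)cc1`) has not yet been measured. Its structure departs from that of compound 2 by methoxymethyl in place of methoxy on a saturated chain carbon, two bonds along the chain from an oxygen on an aromatic ring. In plain terms, 2-methoxyethoxy becomes 3-methoxypropoxy.

Among the compounds with values here, the one measured step that bears on this change is a step that the two limits leave unreadable from compound 1 to compound 2. That step lengthened the same chain, and the read-out stayed at the limit, so it offers only a weak guide and gives no size to carry forward. No shift beyond the usual scatter is expected in this assay, and a further limit is the most likely report. The expected change is a step that the limit leaves unreadable from compound 2 to compound 3. For compound 3 the estimate is 45000 nM, with an expected range from 20000 nM to 100000 nM.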

Compound 3, half-maximal inhibitory concentration: > 40000 nM
Compound 3: no number, only a limit (the forecaster's own chance of this, stated with the estimate: 85%); the middle value is on the limit's open side.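

Compound 3, like compound 1 and compound 2, gives only a limit and not a number in this assay, so no step among these compounds can be read: the limit of > 40000 nM in this assay, at which 3 of the 3 values shown sit.

The compounds shown leave open what exact value each of the three would have, and whether changing this ether chain shifts the read-out at all.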